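The source may hold more compounds than are shown below. What is called first, only, known or untested is meant among the compounds shown, and "the series" means these compounds.

In a functional assay on HeLa cells (Homo sapiens) for cytotoxicity, read by MTT assay (a higher number here means a weaker inhibitor, a lower number a stronger inhibitor), compound 2 `CC(C)[C@H](NC(=S)Nc1ccccc1)c1nc2ccccc2[nH]1` gives 11100 nM, the lowest of the two numbers in this set. Its neighbour compound 1 `CC(C)[C@H](NC(=S)NCc1ccccc1)c1nc2ccccc2[nH]1` gives 49900 nM in this assay, and the step from the one to the other, phenyl in place of benzyl on an amide-type nitrogen, is a 4.5-fold lower number from compound 1 to compound 2 (0.65 log units; beyond the scatter). Compound 3 `CC(C)[C@@H](NC(=S)Nc1ccccc1)c1nc2ccccc2[nH]1` is reported in this assay as "not active" (no number reported); it differs from compound 2 only in the configuration as drawn (the fact that compounds 2 and 3 differ only in the configuration as drawn).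

Compound 4 `C[C@H](NC(=S)Nc1ccccc1)c1nc2ccccc2[nH]1` has not been measured. It differs from compound 2 by methyl in place of isopropyl on a saturated chain carbon bound to an amide-type nitrogen and an aromatic carbon. For the measured compounds named here, no measured step touches that chain carbon; the one step available, from compound 1 to compound 2, changes the group on the nitrogen instead, so it gives only a loose guide to size. A modest change, within or just beyond the scatter, is therefore expected. For compound 4 the number in this assay is estimated at 20000 nM, in a range from 6000 nM to 70000 nM. The expected step from compound 2 to compound 4 is a 1.8-fold higher number from compound 2 to compound 4 (0.26 log units; within the scatter).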

Compound 4, half-maximal inhibitory concentration: "not active" (no number reported)
For compound 4 the study gives words and no number; no gap can be computed for the estimate.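

Compound 4 is reported only in words, as "not active", so no new step can be read from compound 2 to compound 4. Nothing available explains this result. The compounds shown leave open how this assay responds to groups other than methyl and isopropyl on that chain carbon.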